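A few compounds are considered here, and "the series" means these few. Any claim that something is new, unique, unknown or untested is made for them only; others in the source may bear on it.

The series shares the core of compound 1 `O=C(Nc1sc2c(c1C(=O)NNc1ccccc1)CCCCC2)NS(=O)(=O)c1ccccc1`, which in a functional assay on cells (Leukemia cell, Homo sapiens) for inhibition, with a stated time of 48 h (on this read-out higher numbers stand for weaker inhibition of growth and lower numbers for stronger inhibition of growth), gives 18600 nM. Compound 2 `CCCCNC(=O)c1c(NC(=O)NS(=O)(=O)c2ccccc2)sc2c1CCCCC2` carries butyl in place of anilino on the amide-type nitrogen. In this assay compound 2 reaches only a limit of the method, > 100000 nM. The step of an at least 5.3-fold higher number from compound 1 to compound 2 (0.73 log units; beyond the scatter) therefore rests on the limit of > 100000 nM in this assay, at which 1 of the 2 values shown sits, and its full size is open. Compound 3 `O=C(Nc1sc2c(c1C(=O)N1CCN(c3ccccc3)CC1)CCCCC2)NS(=O)(=O)c1ccccc1` differs from compound 2 by 4-phenylpiperazin-1-yl in place of butylamino on a carbonyl carbon. For the measured compounds named here, one measured step bears on this change, the loss of anilino for butyl, which moved the number beyond the scatter; the change to compound 3 returns an aromatic ring to the carbonyl side, now within 4-phenylpiperazin-1-yl. For compound 3 the number in this assay is expected to fall back toward that of compound 1, an estimated step of an at least 3.3-fold lower number from compound 2 to compound 3 (0.52 log units; beyond the scatter). Compound 3 is estimated at 30000 nM, with a range from 8000 nM to 100000 nM.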

Compound 3, concentration for 50% growth inhibition: > 100000 nM
Compound 3 ended at the assay's limit (the forecaster's own chance of this, stated with the estimate: 30%); at least 3.3-fold (0.52 log units) between middle value and limit.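

In this assay, 4-phenylpiperazin-1-yl on the carbonyl carbon gives an at least 5.3-fold higher number from compound 1 to compound 3 (0.73 log units; beyond the scatter), so a second replacement of the anilinoamino group also loses the number seen for compound 1. Compound 3 carries a phenyl ring within its new group, and that ring alone does not bring back a readable number; of the three compounds, only compound 1 gives a value that is not a limit. The step from compound 2 to compound 3 cannot be read, and no order between the two can be given: the limit of > 100000 nM in this assay, at which 2 of the 3 values shown sit.

Open, from the compounds shown here alone, is whether the number for compound 1 depends on the nitrogen-nitrogen link or on its phenyl ring. A benzylamino group or an unsubstituted hydrazine on the same carbonyl carbon would separate the two.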